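A Piperazine Side Chain on Compound 2

The compounds below may be only part of what the source reports. "The series", "measured", "known", "first", "only" and "open" are said of these compounds alone.

Among the measured compounds shown here, in a functional assay on SK-BR-3 cells (Homo sapiens) for antiproliferative activity, read by MTT assay, with a stated time of 72 h (a lower number here means a stronger inhibitor, a higher number a weaker inhibitor), compound 2 `CCNc1cc(C)c2cc(NC(=O)c3ccc(Cl)c(Cl)c3)ccc2n1` gives 28200 nM as the highest of the three numbers so far. Compound 1 `CCN1CCN(c2cc(C)c3cc(NC(=O)c4ccc[nH]4)ccc3n2)CC1` at 13200 nM and compound 3 `CCN1CCN(c2cc(C)c3cc(NC(=O)c4ccc(Br)cc4)ccc3n2)CC1` at 6310 nM both stand lower, beyond the scatter. Compound 4 `Cc1cc(NCCN2CCN(C)CC2)nc2ccc(NC(=O)c3ccc(Cl)c(Cl)c3)cc12` differs from compound 2 in one place: 4-methylpiperazin-1-yl in place of hydrogen on a saturated chain carbon, two bonds along the chain from a nitrogen on an aromatic ring turns ethylamino into (2-(4-methylpiperazin-1-yl)ethyl)amino. For the measured compounds named here, the only measured step is a 2.1-fold lower number from compound 1 to compound 3 (0.32 log units; beyond the scatter) and it is modest, but it concerns the group on a carbonyl carbon, so it says nothing directly about this place. Going by the values given here, no measured pair isolates the change. Compounds 1 and 3 do carry a six-membered non-aromatic ring with 2 hetero atoms that compound 2 lacks, yet they also differ from compound 2 on the carbonyl carbon, so this is only a weak hint. A modest move to a lower number is therefore expected, with a 2.8-fold lower number from compound 2 to compound 4 (0.45 log units; beyond the scatter) as the estimated step. For compound 4 the estimate is 10000 nM in a range from 3000 nM to 30000 nM as expected limits of the measurement.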

Compound 4, half-maximal inhibitory concentration: 2690 nM
Compound 4: the middle estimate sits 3.7-fold (0.57 log units) above what was measured; measured number outside the range, below it.
By their numbers in this assay, from the lowest: compound 4; then compound 3; then compound 1; then compound 2.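

In this assay the change from ethylamino to (2-(4-methylpiperazin-1-yl)ethyl)amino gives a 10-fold lower number from compound 2 to compound 4 (1.02 log units; beyond the scatter) as the first step measured at this position, and it is a large one. Among the compounds shown here, the only earlier step, a 2.1-fold lower number from compound 1 to compound 3 (0.32 log units; beyond the scatter) on a carbonyl carbon, was modest, so this pair shows that a change on the saturated chain alone, with the rest of compound 2 kept, can shift the number much further. Nothing measured here accounts for the size of this step.

As far as these compounds go, what stays open is whether the 4-methylpiperazin-1-yl ring as a whole is needed, or whether a simpler dimethylamino group or a morpholine ring at the end of the same chain would do as much. Also open, from the compounds shown here alone, is how a longer chain between the ring and the nitrogen on the aromatic ring would read, and whether the step holds with other groups on the carbonyl carbon.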